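Notes on the step from compound 3 to compound 4

A few compounds are considered here, and "the series" means these few. Any claim that something is new, unique, unknown or untested is made for them only; others in the source may bear on it.

Compound 3 `COc1cc(OC)cc(C(=O)Nc2cc(-c3ccccc3)nn2-c2ccccc2)c1` gives 2040 nM in a functional assay on cells for positive allosteric modulation of metabotropic glutamate receptor 5 (Rattus norvegicus), read by calcium flux (on this read-out lower numbers stand for an effect already at smaller amounts and higher numbers for an effect only at larger amounts of compound), the highest number of the three measured. Compound 1 `O=C(Nc1cc(-c2ccccc2)nn1-c1ccccc1)c1cccc([N+](=O)[O-])c1` gives 39 nM and compound 2 `COc1ccc(C(=O)Nc2cc(-c3ccccc3)nn2-c2ccccc2)cc1` gives 54 nM. The two steps that lead into compound 3 are both large: a 52-fold higher number from compound 1 to compound 3 (1.72 log units; beyond the scatter) and a 38-fold higher number from compound 2 to compound 3 (1.58 log units; beyond the scatter); in contrast, a 1.4-fold higher number from compound 1 to compound 2 (0.14 log units; within the scatter). Compound 4 `O=C(Nc1cc(-c2ccccc2)nn1-c1ccccc1)c1ccc(Cl)c(Cl)c1` carries 3,4-dichlorophenyl in place of 3,5-dimethoxyphenyl on a carbonyl carbon. Among the compounds with values here, the steps that bear on it are those removing 3,5-dimethoxyphenyl, so a large move to lower numbers in this assay, back toward compound 1 and compound 2, is expected. Within the data shown here, the 3,4-dichlorophenyl itself has no measured counterpart here, so the landing point is uncertain. Compound 4 is expected at 80 nM, range 20 nM to 500 nM. The expected step is a 26-fold lower number from compound 3 to compound 4 (1.41 log units; beyond the scatter).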

Compound 4, half-maximal effective concentration: 13 nM
Compound 4: middle estimate off by 6.2-fold (0.79 log units), on the high side; measured number outside the range, below it.
By their numbers in this assay, from the lowest: compound 4; then compounds 1 and 2 (each within the scatter of the next); then compound 3.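

On the carbonyl carbon, the 3,4-dichlorophenyl does more than undo the loss seen with the 3,5-dimethoxyphenyl in this assay (a 160-fold lower number from compound 3 to compound 4 (2.20 log units; beyond the scatter)): it also improves on both earlier groups (a 4.2-fold lower number from compound 2 to compound 4 (0.62 log units; beyond the scatter); a 3.0-fold lower number from compound 1 to compound 4 (0.48 log units; beyond the scatter)). A phenyl with two substituents therefore does not in itself bring the high number of compound 3, and the identity of those substituents matters at this position. Nothing available here explains these steps.

Going by these compounds, it remains open whether a single chlorine, an amine or a carboxylic acid on this phenyl would keep the number as low. On these data alone, the effect of the 3,4-dichlorophenyl on any other version of the shared core also remains open.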